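Notes on an acyl-group change in a cytotoxicity series

The compounds below may be only part of what the source reports. "The series", "measured", "known", "first", "only" and "open" are said of these compounds alone.

Compound 3 `CCC(=O)Nc1cccc(Sc2c(OC)nc(N3CCN(C)CC3)nc2OC)c1` is characterised in a functional assay on SK-BR-3 cells (Homo sapiens) for cytotoxicity, read by resazurin assay, with a stated time of 72 h (on this read-out lower numbers stand for stronger inhibition of growth and higher numbers for weaker inhibition of growth), where compound 3 gives 55 uM. Compound 2 `CCOc1nc(N2CCN(C)CC2)nc(OCC)c1Sc1nc(N)cc(NC(=O)CC)n1` gives 55 uM in this assay, level with compound 3 at the digits shown; the two together are the highest numbers in the set. Compound 1 `C=CC(=O)Nc1cc(N)nc(Sc2c(OCC)nc(N3CCN(C)CC3)nc2OCC)n1` gives 1.1 uM and stands far lower. Within the data shown here, the only step measured between single-change neighbours is a 50-fold higher number from compound 1 to compound 2 (1.70 log units; beyond the scatter), which arises from ethyl in place of vinyl on a carbonyl carbon.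

Compound 4 `COc1nc(N2CCN(C)CC2)nc(OC)c1Sc1cccc(NC(=O)CN)c1` is not yet measured. It differs from compound 3 by amino in place of methyl on a saturated chain carbon bound to a carbonyl carbon. The step from compound 1 to compound 2 also touches the group on the carbonyl, but it exchanges vinyl for ethyl, not methyl for amino, so it gives no direct reading for this change. Among the measured compounds shown here, with no matching precedent, compound 4 is expected to move from compound 3 by a 1.2-fold lower number from compound 3 to compound 4 (0.09 log units; within the scatter), that is, no step beyond the scatter. Compound 4 is therefore estimated at 45 uM, within 12 uM to 160 uM.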

Compound 4, concentration for growth inhibition (reported as GI): 25 uM
Compound 4: middle estimate off by 1.8-fold (0.26 log units), on the high side; measured number inside the range.
By their numbers in this assay, from the lowest: compound 1; then compound 4; then compounds 2 and 3 (each within the scatter of the next).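

Amino in place of methyl on a saturated chain carbon bound to a carbonyl carbon gives a 2.2-fold lower number from compound 3 to compound 4 (0.34 log units; beyond the scatter) in this assay and this modest step lies just beyond the scatter. Among these compounds, the only earlier reading on the group carried by the carbonyl was the exchange of vinyl for ethyl, which gave the much larger a 50-fold higher number from compound 1 to compound 2 (1.70 log units; beyond the scatter) and now a change at the saturated chain carbon has a reading of its own. Nothing measured here bears on why the number moves.

The compounds shown leave open whether a hydroxyl, a dimethylamino group or a longer chain ending in an amine at this chain carbon moves the number further than amino does. Also open, going by these compounds, is whether ((aminomethyl)carbonyl)amino in place of propanoylamino gives a step of similar size on the core of compound 2.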